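Chloro for hydrogen on a dihydroxyphenyl pyrazole

The source may report more compounds than this note shows. Statements on the series, on what has been measured and on what is new or still open speak of the compounds shown alone.

Measured compounds:
- compound 1, `COc1ccc(OC)c(-c2cc(-c3ccccc3)nn2-c2ccc(S(=O)(=O)NC(C)=O)cc2)c1`: in a functional assay on cells (Cancer cell lines, Homo sapiens) for cytotoxicity, read by sulforhodamine B assay, with a stated time of 48 h (on this read-out lower numbers stand for stronger inhibition of growth and higher numbers for weaker inhibition of growth), compound 1 gives 50700 nM
- compound 2, `COc1ccc(OC)c(-c2cc(-c3ccc(Cl)cc3)nn2-c2ccc(S(=O)(=O)NC(C)=O)cc2)c1`: in this assay compound 2 gives 67100 nM
- compound 3, `Oc1ccc(O)c(-c2cc(-c3ccccc3)nn2-c2ccccc2)c1`: in this assay compound 3 gives 75300 nM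

The three numbers lie close together; the values of compound 1, compound 2 and compound 3 are all within the scatter of one another, so no order among them can be read. For the measured compounds named here, the one single-point step that has been measured is a 1.3-fold higher number from compound 1 to compound 2 (0.12 log units; within the scatter), the change being (chloro in place of hydrogen on an aromatic carbon).

Compound 4, `Oc1ccc(O)c(-c2cc(-c3ccc(Cl)cc3)nn2-c2ccccc2)c1`, has not yet been measured in this assay. It relates to compound 3 as compound 2 relates to compound 1: the change is chloro in place of hydrogen on an aromatic carbon. The two place descriptions agree word for word, so this is the same kind of change made on a different core. How the core of compound 3 differs from the core of compound 1 is not broken down here.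

The expectation for compound 4 rests on the step measured on the other core: since the chloro for hydrogen exchange gave a 1.3-fold higher number from compound 1 to compound 2 (0.12 log units; within the scatter), a step of about the same, small size is expected from compound 3 to compound 4, namely a 1.2-fold higher number from compound 3 to compound 4 (0.08 log units; within the scatter). With that, compound 4 is estimated at 90000 nM in this assay, with a plausible range from 45000 nM to 180000 nM; a value at the weak end of the measured range would not be surprising, and the estimate is anchored only by the value of compound 3, 75300 nM.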

Compound 4, concentration for total growth inhibition: 60400 nM
Compound 4: middle estimate off by 1.5-fold (0.17 log units), on the high side, and the stated range covers the measured number.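

In this assay, for the compounds shown here, chloro in place of hydrogen on an aromatic carbon gives a 1.2-fold lower number from compound 3 to compound 4 (0.10 log units; within the scatter), so on this second core, as on the first, the exchange yields no step that can be told from the scatter. Set side by side, the two steps do not differ: the same change on two cores in this assay, a 1.3-fold higher number (0.12 log units; within the scatter) from compound 1 to compound 2 and a 1.2-fold lower number (0.10 log units; within the scatter) from compound 3 to compound 4, 1.6-fold (0.22 log units) apart, within the scatter of two such steps. This agreement is between two steps that are both within the scatter, so it shows only that phenyl to 4-chlorophenyl has no readable consequence on either core in this assay; it does not show that an effect of a defined size or direction carries over, the opposite directions of the two steps have no meaning, and two cores say nothing about a third.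

Still open, as far as these compounds go, is whether any other group at the same place, such as an amine, a carboxylic acid, a methoxy group or a longer alkyl chain, would give a step beyond the scatter on either core. Going by these compounds alone, also open is which of the parts that separate the core of compound 1 from the core of compound 3 matter in this assay, since no single-point step between those two cores is available here.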